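This account rests on a few compounds, and the source may have more. Where it says the series, first, only, none or still open, it means among the compounds named here.

Measured in a functional assay on MCF7 cells (Homo sapiens) for cytotoxicity, read by MTT assay, with a stated time of 48 h; a higher number here means a weaker inhibitor, a lower number a stronger inhibitor:
- compound 1 `COc1ccc2c(c1)C(C)=CC(C)(C)N2Cc1cn(Cc2cc3cc(OC)ccc3nc2Cl)nn1`: 26400 nM
- compound 2 `CC1=CC(C)(C)N(Cc2cn(Cc3cc4cc(C)ccc4nc3Cl)nn2)c2ccccc21`: 30600 nM

In this assay compound 2 gives 30600 nM, which lies within the scatter of compound 1 at 26400 nM. Compound 3 `COc1ccc2nc(Cl)c(Cn3cc(CN4c5ccccc5C(C)=CC4(C)C)nn3)cc2c1` follows from compound 2 through (methoxy in place of methyl on an aromatic carbon), with methoxy in place of methyl on an aromatic carbon. Among the measured compounds shown here, no measured pair isolates this change, so the expectation rests only on these two values, which sit close together. No shift beyond the scatter is expected, and the estimated change is a 1.1-fold lower number from compound 2 to compound 3 (0.04 log units; within the scatter). For compound 3 the estimate is 28000 nM, with an expected range of 14000 nM to 55000 nM.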

Compound 3, half-maximal inhibitory concentration: 38700 nM
Beside the measured number, compound 3's estimate is 1.4-fold (0.14 log units) below it; measured number inside the range.
By their numbers in this assay, from the lowest: compounds 1, 2 and 3 (each within the scatter of the next).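

Methoxy in place of methyl on an aromatic carbon gives a 1.3-fold higher number from compound 2 to compound 3 (0.10 log units; within the scatter) in this assay and provides the first measured pair for this change. Hydrogen in place of methoxy on an aromatic carbon gives a 1.5-fold higher number from compound 1 to compound 3 (0.17 log units; within the scatter) and likewise brings no shift beyond the scatter, so neither exchange separates these compounds. Nothing at hand accounts for these steps. From the compounds shown here alone, whether an amine or a carboxylic acid on this aromatic carbon would move the number beyond the scatter remains open. Which part of the shared core governs the read-out also remains open.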